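The source may report more compounds than this note shows. Statements on the series, on what has been measured and on what is new or still open speak of the compounds shown alone.

Of the compounds shown here, three sharing one core have been measured in an in vitro functional assay on HEK285-7 cells for antagonist activity at prostaglandin D2 receptor 2 (Homo sapiens), read by BRET and beta-arrestin recruitment; a higher number here means a larger maximal response, a lower number a smaller maximal response. Compound 1 `COc1cc(-c2nc(C(c3ccc(F)cc3)c3ccc(F)cc3)sc2CC(=O)O)ccn1` carries a 2-methoxypyridin-4-yl group, and in this assay compound 1 gives 60%. Compound 2 `O=C(O)Cc1sc(C(c2ccc(F)cc2)c2ccc(F)cc2)nc1-c1cccc(F)c1` carries a 3-fluorophenyl group in the same place, and compound 2 gives 80%. Compound 3 `O=C(O)Cc1sc(C(c2ccc(F)cc2)c2ccc(F)cc2)nc1-c1ccco1` carries a furan-2-yl group there, and compound 3 gives 80%. Compound 3 stands level with compound 2 at the digits printed, the two together the highest of the three numbers, while compound 1 lies a number 20 percentage points higher from compound 1 to compound 3 (beyond the scatter) and a number 20 percentage points higher from compound 1 to compound 2 (beyond the scatter). Between the two higher compounds there is no change at the digits printed from compound 2 to compound 3 (within the scatter).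

Compound 4 `CN(C)c1cc(-c2nc(C(c3ccc(F)cc3)c3ccc(F)cc3)sc2CC(=O)O)ccn1` has not been measured. It differs from compound 3 as follows: 2-(dimethylamino)pyridin-4-yl in place of furan-2-yl on an aromatic carbon. The step from compound 1 to compound 3 bears on this change, since it moved away from a six-membered ring with one hetero atom, and compound 4 returns to such a ring; so does the step from compound 2 to compound 3, which shows that the two non-pyridine groups behaved alike. The return is expected to cost some efficacy, though probably not all of it. Compound 4 is therefore expected to give 68%, with a range from 50% to 85%. That expectation corresponds to a number 12 percentage points lower from compound 3 to compound 4 (beyond the scatter).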

Compound 4, largest response reached (reported as efficacy), in percent of the reference or control that the assay uses: 80%
Estimate against measurement, compound 4: 12 percentage points below, within the range that was stated.
By their numbers in this assay, from the lowest: compound 1; then compounds 2, 3 and 4 (each within the scatter of the next).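

In this assay, a six-membered aromatic ring with 1 hetero atom on this aromatic carbon does not by itself go with the lower number: 2-(dimethylamino)pyridin-4-yl in place of furan-2-yl gives no change at the digits printed from compound 3 to compound 4 (within the scatter) and, in place of 3-fluorophenyl, gives no change at the digits printed from compound 2 to compound 4 (within the scatter) in the same assay. The two compounds that carry such a ring differ only in the group on it, and dimethylamino in place of methoxy gives a number 20 percentage points higher from compound 1 to compound 4 (beyond the scatter), so among these four compounds the lower number of compound 1 goes with its methoxy group and not with the ring that carries it. Nothing at hand bears on why the numbers fall this way.

As far as these compounds go, it remains open whether other groups in the place of that methoxy, such as a primary amine, a morpholine ring or an ethoxy chain, would stand with compound 1 or with compound 4. From the compounds shown here alone, it also remains open whether a thiophene ring or a carboxamide in the place of the furan-2-yl group of compound 3 would give a number level with those of compound 2, compound 3 and compound 4.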